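Swapping the amide-nitrogen ring for a saturated heterocycle

This account rests on a few compounds, and the source may have more. Where it says the series, first, only, none or still open, it means among the compounds named here.

Three amides sharing one core have been measured in an assay on isolated protein for inhibition of phosphodiesterase 4A (Sus scrofa); a higher number here means a weaker inhibitor, a lower number a stronger inhibitor. Compound 1 `COc1ccc(C(=O)Nc2ccccc2Cl)cc1OC1CCCC1` gives 190 nM, and compound 2 `COc1ccc(C(=O)Nc2ccccc2Br)cc1OC1CCCC1` gives 130 nM; the step of a 1.5-fold lower number from compound 1 to compound 2 (0.16 log units; within the scatter) is small. Compound 3 `COc1ccc(C(=O)Nc2ncccc2C)cc1OC1CCCC1` gives 3100 nM, the highest of the three numbers, set apart from the others by the steps of a 16-fold higher number from compound 1 to compound 3 (1.21 log units; beyond the scatter) and a 24-fold higher number from compound 2 to compound 3 (1.38 log units; beyond the scatter).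

Compound 4 `COc1ccc(C(=O)NC2(C)C=C(C)ON2)cc1OC1CCCC1` differs from compound 3 in one place: a group of 7 heavy atoms (5 carbon, 1 nitrogen, 1 oxygen; one five-membered non-aromatic ring with 2 hetero atoms) in place of a group of 7 heavy atoms (6 carbon, 1 nitrogen; one six-membered aromatic ring with 1 hetero atom), on an amide-type nitrogen. Going by the values given here, no measured step covers this particular exchange. The two steps that do change the group on the amide-type nitrogen, from compound 1 and compound 2 to compound 3, were both large, which shows that this position moves the number strongly, but they give no direction for a ring that is neither aromatic nor the halogenated phenyl of compound 1 and compound 2. The expectation for compound 4 is therefore uncertain and leans towards a somewhat higher number, with the step of a 1.9-fold higher number from compound 3 to compound 4 (0.29 log units; within the scatter) expected. In this assay compound 4 is estimated at 6000 nM, within a range from 1500 nM to 25000 nM.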

Compound 4, half-maximal inhibitory concentration: 450 nM
Compound 4: middle estimate off by 13-fold (1.12 log units), on the high side, and the stated range ends above it.
By their numbers in this assay, from the lowest: compounds 2 and 1 (each within the scatter of the next); then compound 4; then compound 3.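

In this assay, the change of ring on the amide-type nitrogen can also lower the number, as a 6.9-fold lower number from compound 3 to compound 4 (0.84 log units; beyond the scatter) shows, so at this place an aromatic ring is not needed for a lower number than that of compound 3. The new ring still does not match the halogenated phenyl rings, with a 3.5-fold higher number from compound 2 to compound 4 (0.54 log units; beyond the scatter) and a 2.4-fold higher number from compound 1 to compound 4 (0.37 log units; beyond the scatter), which places compound 4 between those two compounds and compound 3. No measurement on these compounds gives a reason for these shifts.

Because ring size, aromatic character, the ring oxygen and the amide-side hydrogen-bond donor all change together in compound 4, the compounds shown cannot say which of these changes goes with the step. On these data alone, how an open butyl chain or a carboxylic acid on this nitrogen would compare also remains open.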